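Compound 4: benzoyl in place of 1-benzothiophen-2-yl

The source may hold more compounds than are shown below. What is called first, only, known or untested is meant among the compounds shown, and "the series" means these compounds.

In an ADME assay on cells (Fibroblast, Gallus gallus) for cytotoxicity, read by CCK-8 assay, with a stated time of 48 h (a higher number here means that more compound is tolerated, a lower number that less compound is tolerated), compound 3 `CCC(CC)O[C@@H]1C=C(C(=O)O)C[C@H](NCc2ccc(-c3cc4ccccc4s3)cc2)[C@H]1NC(C)=O` gives > 200000 nM, a limit and not a number. Compound 1 `CCC(CC)O[C@@H]1C=C(C(=O)O)C[C@H](NCc2ccc(C(C)C)cc2)[C@H]1NC(C)=O` gives > 200000 nM, likewise a limit. Compound 2 `CCC(CC)O[C@@H]1C=C(C(=O)O)C[C@H](NCc2ccc(SC3CCCCC3)cc2)[C@H]1NC(C)=O` gives > 200000 nM, also a limit.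

Compound 4 `CCC(CC)O[C@@H]1C=C(C(=O)O)C[C@H](NCc2ccc(C(=O)c3ccccc3)cc2)[C@H]1NC(C)=O` carries benzoyl in place of 1-benzothiophen-2-yl on an aromatic carbon.

Three measured steps exchange the group at this place: a step that the two limits leave unreadable from compound 1 to compound 2, a step that the two limits leave unreadable from compound 1 to compound 3 and a step that the two limits leave unreadable from compound 2 to compound 3. None of them has a readable size, and together they show only (the limit of > 200000 nM in this assay, at which 3 of the 3 values shown sit). The expectation for the new step therefore follows compound 3 through a step that the two limits leave unreadable from compound 2 to compound 3 and rests on no measured number. In this assay a step of a number no higher from compound 3 to compound 4 (the limit leaves the size open) is expected, with no direction and nothing beyond the scatter. Compound 4 is estimated at 200000 nM, with an expected range of 100000 nM to 400000 nM, and it will most likely be reported only as a limit.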

Compound 4, half-maximal cytotoxic concentration: > 200000 nM
Compound 4: no number, only a limit; the forecaster's own chance of this, stated with the estimate: 85%; the middle value lies on the limit itself.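

In this assay, the steps to compound 4 from compound 1, compound 2 and compound 3 cannot be read, since all four compounds give only a limit: the limit of > 200000 nM in this assay, at which 4 of the 4 values shown sit.

The compounds shown leave open whether the groups at this place differ at all in this assay.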